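Replacing the phenethyl group: a cytotoxicity estimate

This account rests on a few compounds, and the source may have more. Where it says the series, first, only, none or still open, it means among the compounds named here.

In an ADME assay on HOS cells (Homo sapiens) for cytotoxicity, read by luminescence and ATP content, with a stated time of 48 h (on this read-out higher numbers stand for lower toxicity in this test and lower numbers for higher toxicity in this test), compound 1 (`COc1ccc2c(N)c(C(=O)NCc3ccc(F)cc3F)c(=O)n(O)c2n1`) gives 2200 nM and compound 2 (`Nc1c(C(=O)NCc2ccc(F)cc2F)c(=O)n(O)c2ncc(CCc3ccccc3)cc12`) gives 18000 nM as the higher of the two numbers. The gap between them lies beyond the usual scatter, and compound 2 is the less toxic of the pair in this test.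

Compound 3 (`CN(C)C(=O)/C=C/c1cnc2c(c1)c(N)c(C(=O)NCc1ccc(F)cc1F)c(=O)n2O`) carries 2-(dimethylcarbamoyl)ethenyl in place of phenethyl on an aromatic carbon. Among the compounds with values here, no measured pair shows this change, so any forecast is loose. Compound 1 has no phenethyl group and stands at 2200 nM in this assay, which makes a fall toward that number seem likelier than a further rise. The expected change is a moderate step to a lower number, a 3.0-fold lower number from compound 2 to compound 3 (0.48 log units; beyond the scatter), meaning somewhat higher toxicity. For compound 3 the estimate is 6000 nM, with 1500 nM to 25000 nM as the expected range.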

Compound 3, half-maximal cytotoxic concentration: > 250000 nM
Compound 3: only a limit was reported (the forecaster's own chance of this, stated with the estimate: 10%); at least 41-fold (1.61 log units) between middle value and limit.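

This position on the aromatic carbon has a strong influence in this assay: putting 2-(dimethylcarbamoyl)ethenyl in place of phenethyl gives an at least 13-fold higher number from compound 2 to compound 3 (1.14 log units; beyond the scatter), a large move toward lower toxicity in this test. Losing the six-membered aromatic ring of phenethyl therefore does not raise toxicity here, and the change runs clearly the other way. The full size of the step stays unknown because compound 3 is reported only as a limit: the limit of > 250000 nM in this assay, at which 1 of the 3 values shown sits.

The compounds shown leave open which part of the entering group goes with this shift, the double bond or the dimethyl amide at its end. A saturated chain ending in the same dimethyl amide, or a carboxylic acid or a simple amine at the same carbon, would help to separate these parts.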